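From pentylcarbonyl to propanoyl in an antiproliferative series

The source may report more compounds than this note shows. Statements on the series, on what has been measured and on what is new or still open speak of the compounds shown alone.

Measured in a functional assay on MCF7 cells (Homo sapiens) for antiproliferative activity, read by MTT assay, with a stated time of 72 h; a lower number here means a stronger inhibitor, a higher number a weaker inhibitor
- compound 1 `COc1ccc(C(=O)Oc2ccc(C(=O)C3=C4OC(C)(C)[C@@H](CC=C(C)C)C[C@@]45C[C@@H](CC=C(C)C)C(C)(C)[C@H]4CCC(C)(C)O[C@]45OC3=O)cc2OC(=O)c2ccc(OC)cc2)cc1` gives > 20000 nM (a limit of the assay)
- compound 2 `CC(C)=CC[C@H]1C[C@]23C[C@@H](CC=C(C)C)C(C)(C)[C@H]4CCC(C)(C)O[C@]42OC(=O)C(C(=O)c2ccc(OC(=O)c4ccccc4)c(OC(=O)c4ccccc4)c2)=C3OC1(C)C` gives > 20000 nM (a limit of the assay)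
- compound 3 `CCCCCC(=O)Oc1cc(C(=O)C2=C3OC(C)(C)[C@@H](CC=C(C)C)C[C@@]34C[C@@H](CC=C(C)C)C(C)(C)[C@H]3CCC(C)(C)O[C@]34OC2=O)ccc1O` gives 15500 nM

Of these three results, only compound 3 has a true number, at 15500 nM. The other two results are limits and not numbers, so they cannot be ranked against it. The ceiling lies close to that one number, and it is described by the limit of > 20000 nM in this assay, at which 2 of the 3 values shown sit.

The next compound is compound 4 `CCC(=O)Oc1cc(C(=O)C2=C3OC(C)(C)[C@@H](CC=C(C)C)C[C@@]34C[C@@H](CC=C(C)C)C(C)(C)[C@H]3CCC(C)(C)O[C@]34OC2=O)ccc1O`. It differs from compound 3 by hydrogen in place of propyl on a saturated chain carbon, two bonds along the chain from a carbonyl carbon. In words, hydrogen stands in place of propyl on a saturated chain carbon, two bonds along the chain from a carbonyl carbon, which turns pentylcarbonyl into propanoyl.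

Among the compounds with values here, no pair of measured compounds shows what this change does in this assay, so the expectation is a cautious one. A small step towards weaker inhibition is expected, or none beyond the scatter. Compound 3 stands at 15500 nM. That leaves little room before the limit, and the assay may report only a limit for the new compound. The expected change is a 1.1-fold higher number from compound 3 to compound 4 (0.04 log units; within the scatter). Compound 4 is estimated at 17000 nM, with an expected range from 9000 nM to 30000 nM.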

Compound 4, half-maximal inhibitory concentration: > 20000 nM
Compound 4: no number, only a limit (the forecaster's own chance of this, stated with the estimate: 45%); middle value at least 1.1-fold (0.07 log units) away from the limit.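

Within the data shown here, this is the first step read at this place, on a saturated chain carbon, two bonds along the chain from a carbonyl carbon: turning pentylcarbonyl into propanoyl gives an at least 1.2-fold higher number from compound 3 to compound 4 (0.11 log units; that floor lies within the scatter). In this assay compound 4 gives > 20000 nM, which is a limit of the assay and not a number. Compound 3 therefore stays the only compound here with a true number, and the pentylcarbonyl chain is the only acyl chain shown at this place that gives one, while the other results gather at a single ceiling: the limit of > 20000 nM in this assay, at which 3 of the 4 values shown sit.

On these data alone, only a floor is known for this step, so its true size stays open, and the step cannot tell whether removing propyl matters a great deal or hardly at all. Whether a longer chain in place of pentylcarbonyl, or a chain carrying an amine, would bring the number in this assay clearly lower cannot be told from the compounds shown.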